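The compounds below may be only part of what the source reports. "The series", "measured", "known", "first", "only" and "open" are said of these compounds alone.

Measured so far:
- compound 1, `COc1cc(CC(O)(COCc2ccccc2)COCc2ccccc2)nc(OC)n1`: > 100000 nM
- compound 2, `COc1nc(CC(O)(COCc2ccccc2)COCc2ccccc2)c(C)c(OC)n1`: 3500 nM

Both compounds were tested in a functional assay on SW-620 cells (Homo sapiens) for antiproliferative activity, read by MTT assay, with a stated time of 72 h; on this read-out higher numbers stand for weaker inhibition and lower numbers for stronger inhibition. For compound 1 the result is only a limit of the assay, (the limit of > 100000 nM in this assay, at which 1 of the 2 values shown sits), so no number for it is known; it is the weaker of the two as far as the data go. Among the compounds with values here, the one measured step, an at least 28-fold lower number from compound 1 to compound 2 (1.45 log units; beyond the scatter), concerns a different part of the molecule.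

Compound 3, `O=c1cc(CC(O)(COCc2ccccc2)COCc2ccccc2)[nH]c(=O)[nH]1`, is not yet measured. It differs from compound 1 by a group of 8 heavy atoms (4 carbon, 2 nitrogen, 2 oxygen; one six-membered aromatic ring with 2 hetero atoms) in place of a group of 10 heavy atoms (6 carbon, 2 nitrogen, 2 oxygen; one six-membered aromatic ring with 2 hetero atoms), on a saturated chain carbon, two bonds along the chain from an oxygen on a saturated carbon. Within the data shown here, no measured step concerns this kind of change, so the only guide is that compound 1 itself stands at the limit, with no number to move away from. Without a step for the exchanged group there is no reason to expect a change beyond the scatter; a result at the limit again is the most plausible outcome for compound 3.

The estimate for compound 3 is therefore 150000 nM, with a range from 30000 nM to 600000 nM, meaning an expected step that the limit leaves unreadable from compound 1 to compound 3.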

Compound 3, half-maximal inhibitory concentration: > 100000 nM
Compound 3: a limit, no number (the forecaster's own chance of this, stated with the estimate: 75%); the middle value is on the limit's open side.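

Compound 1 and compound 3 each give only a limit of the assay, not a number, in this assay, and no step between them can be read: the limit of > 100000 nM in this assay, at which 2 of the 3 values shown sit.

The compounds shown leave open how the group in compound 3 compares with the 2,6-dimethoxypyrimidin-4-yl group of compound 1, whether in the same direction, the opposite direction or not at all.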